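Aryl sulfonyl variation on the shared core

The compounds below may be only part of what the source reports. "The series", "measured", "known", "first", "only" and "open" are said of these compounds alone.

In an assay on isolated protein for displacement of a labelled ligand from metabotropic glutamate receptor 5 (Homo sapiens), with a stated time of 60 min, tested at 1 uM (a higher number here means more inhibition at the concentration tested (going by the name of the read-out), a lower number less inhibition), compound 2 `CC1CCN(c2c(S(=O)(=O)c3cccc(F)c3)cnc3ccc(F)cc23)CC1` gives 76%, and compound 1 `CC1CCN(c2c(S(=O)(=O)c3ccc(Cl)cc3)cnc3ccc(F)cc23)CC1` gives 80%; compound 2 thus stands next to compound 1, the gap between them within the scatter. Going by the values given here, the one measured step, a number 4 percentage points lower from compound 1 to compound 2 (within the scatter), changed the aryl ring on the sulfonyl sulfur and stayed within the scatter. Compound 3 `CC1CCN(c2c(S(=O)(=O)c3ccccc3)cnc3ccc(F)cc23)CC1` differs from compound 2 by hydrogen in place of fluoro on an aromatic carbon. Among the compounds with values here, no measured step removes a fluoro, so a step of a number 2 percentage points lower from compound 2 to compound 3 (within the scatter) is expected, none beyond the scatter, since the aryl change from compound 1 to compound 2 showed a number 4 percentage points lower from compound 1 to compound 2 (within the scatter). Compound 3 is estimated at 74%, range 60% to 86%.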

Compound 3, a percentage reported as inhibition, at one concentration (the size of the read-out at that concentration, not a potency): 40%
For compound 3 the middle estimate is 34 percentage points above the measured one, and the stated range ends above it.
By their numbers in this assay, from the lowest: compound 3; then compounds 2 and 1 (each within the scatter of the next).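

The aryl ring on the sulfonyl sulfur is far more sensitive in this assay than the earlier pair suggested: removing the halogen costs far more than exchanging one halogenated ring for the other, with hydrogen in place of fluoro (a number 36 percentage points lower from compound 2 to compound 3 (beyond the scatter)) and hydrogen in place of chloro (a number 40 percentage points lower from compound 1 to compound 3 (beyond the scatter)). Among these three compounds, both halogenated rings hold up and the unsubstituted phenyl does not. No evidence on hand accounts for this loss.

On these data alone, whether a methyl, methoxy or nitrile group on this ring would serve as well as a halogen remains open. Also open, as far as these compounds go, is how much depends on the identity of the halogen and how much on its place, as 4-chlorophenyl and 3-fluorophenyl differ in both.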